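The source may report more compounds than this note shows. Statements on the series, on what has been measured and on what is new or still open speak of the compounds shown alone.

Measured in an ADME assay on cells (Hepatocyte, Homo sapiens) for metabolic stability; on this read-out lower numbers stand for a shorter-lived compound and higher numbers for a longer-lived compound:
Compound 1 `O=C(NC1CCC(CN2CCN(c3cc(=O)c4cc(C(F)(F)F)cc([N+](=O)[O-])c4s3)CC2)CC1)c1ccccc1`: > 1.55 h, a limit.
Compound 2 `CC(=O)OC1CCC(CN2CCN(c3cc(=O)c4cc(C(F)(F)F)cc([N+](=O)[O-])c4s3)CC2)CC1`: < 0.15 h, a limit.
Compound 3 `CC(=O)NC1CCC(CN2CCN(c3cc(=O)c4cc(C(F)(F)F)cc([N+](=O)[O-])c4s3)CC2)CC1`: > 1.55 h, a limit.

No exact number is available for any of the three. Compound 1 stands at the high end of the values shown, at the limit of > 1.55 h in this assay, at which 2 of the 3 values shown sit.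

Compound 4 `O=C(OC1CCC(CN2CCN(c3cc(=O)c4cc(C(F)(F)F)cc([N+](=O)[O-])c4s3)CC2)CC1)c1ccc(F)cc1` has ((4-fluorophenyl)carbonyl)oxy in place of benzamido on a saturated ring carbon.

The closest evidence is an at least 10-fold lower number from compound 1 to compound 2 (1.01 log units; beyond the scatter), with acetoxy in place of benzamido at the same place. The reverse kind of exchange, acetamido in place of acetoxy, gives an at least 10-fold higher number from compound 2 to compound 3 (1.01 log units; beyond the scatter). Both steps are large. By contrast, a step that the two limits leave unreadable from compound 1 to compound 3, so the group on the carbonyl carbon has no readable effect here. For the measured compounds named here, no measured compound carries the fluorine.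

Resting on the step to compound 2, a large fall is expected, and the expected result is an at least 10-fold lower number from compound 1 to compound 4 (1.01 log units; beyond the scatter). Compound 4 is estimated at 0.15 h, with an expected range from 0.07 h to 0.5 h.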

Compound 4, half-life: 0.0983 h
Compound 4: the middle estimate sits 1.5-fold (0.18 log units) above what was measured; low and high end bracket the measured number.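

In this assay, the ester bearing 4-fluorophenyl gives an at least 15-fold lower number from compound 1 to compound 4 (1.19 log units; beyond the scatter) and an at least 15-fold lower number from compound 3 to compound 4 (1.19 log units; beyond the scatter), so the short half-life at this saturated ring carbon is not confined to acetoxy. Among the compounds shown, the esters, compound 2 and compound 4, sit at the low end and the amides, compound 1 and compound 3, at the high end, and none goes against this. For the compounds shown here, compound 4 gives 0.0983 h, the only value that is not a limit of the assay.

From the compounds shown here alone, the step from compound 2 to compound 4 cannot be read, so the effect of 4-fluorophenyl in place of methyl on a carbonyl carbon stays open. Also open, going by these compounds, is how a urea, a carbamate or a simple amine at the same saturated ring carbon would behave in this assay.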